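The source may report more compounds than this note shows. Statements on the series, on what has been measured and on what is new or still open speak of the compounds shown alone.

Measured in a functional assay on A549 cells (Homo sapiens) for cytotoxicity, read by WST assay, with a stated time of 24 h; a higher number here means a weaker inhibitor, a lower number a stronger inhibitor:

Compound 1, `N#C/C(=C\c1c[nH]c2cc(F)ccc12)C(=O)c1c[nH]c2ccccc12`: 17000 nM
Compound 2, `COc1ccc2c(/C=C(\C#N)C(=O)c3c[nH]c4ccccc34)c[nH]c2c1`: 9600 nM
Compound 3, `N#C/C(=C\c1cn(Cc2ccc(Cl)cc2)c2ccccc12)C(=O)c1c[nH]c2cc(F)ccc12`: the assay reports only a limit, > 50000 nM

Compounds 1 and 2 share one core and differ in a single place: methoxy in place of fluoro on an aromatic carbon. That change made the step of a 1.8-fold lower number from compound 1 to compound 2 (0.25 log units; within the scatter), so the two values show no real difference.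

Compound 4, `COc1ccc2c(C(=O)/C(C#N)=C/c3cn(Cc4ccc(Cl)cc4)c4ccccc34)c[nH]c2c1`, has not been measured yet. Within the data shown here, it differs from compound 3 in one place, (methoxy in place of fluoro on an aromatic carbon), the same change as the one from compound 1 to compound 2, made at the same kind of position. The difference between the core of compound 1 and the core of compound 3 is not broken down here. For compound 3 only the limit of > 50000 nM in this assay, at which 1 of the 3 values shown sits, is known, so the starting point of the step is itself not a number.

Resting on the step from compound 1 to compound 2, which stayed within the scatter, the expected step from compound 3 to compound 4 in this assay is a step that the limit leaves unreadable from compound 3 to compound 4. Compound 4 is therefore expected to give about 60000 nM, somewhere between 25000 nM and 150000 nM, and most likely this assay will again report only a limit for compound 4.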

Compound 4, half-maximal inhibitory concentration: > 50000 nM
Compound 4 ended at the assay's limit; the forecaster's own chance of this, stated with the estimate: 70%; the middle value lies beyond the limit too.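

In this assay compound 3 and compound 4 each give only a limit and not a number, so no step from one to the other can be read: the limit of > 50000 nM in this assay, at which 2 of the 4 values shown sit.

The compounds shown leave open whether methoxy in place of fluoro changes the result at all on the core of compound 3, and what actual number either compound would give.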